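The compounds below may be only part of what the source reports. "The series", "measured", "known", "first", "only" and "open" are said of these compounds alone.

Three compounds that share one core and differ only in the group on the saturated chain carbon bound to an aromatic nitrogen have been tested in a functional assay on A 172 cells (Homo sapiens) for cytotoxicity, read by colorimetric assay and MTT assay; on this read-out lower numbers stand for stronger inhibition and higher numbers for weaker inhibition. Compound 1 `CCOC(=O)Cn1c(=O)c(-c2ccc(OC)cc2)cc2c(OC)cc(OC)cc21`, with ethoxycarbonyl at that place, gives 10000 nM. Compound 2 `COc1ccc(-c2cc3c(OC)cc(OC)cc3n(CC#N)c2=O)cc1`, with cyano there, gives 10000 nM. Compound 3 `COc1ccc(-c2cc3c(OC)cc(OC)cc3n(CC(=O)O)c2=O)cc1`, with carboxy there, gives 10000 nM, so it stands level with the other two.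

The next structure is compound 4 `CCN(CC)C(=O)CCn1c(=O)c(-c2ccc(OC)cc2)cc2c(OC)cc(OC)cc21`. It keeps the shared core and changes the same place: (diethylcarbamoyl)methyl in place of carboxy on a saturated chain carbon bound to an aromatic nitrogen. In short, (diethylcarbamoyl)methyl replaces carboxy.

Among the compounds with values here, three measured steps bear on this change, since each alters the group at that place: no change at the digits printed from compound 1 to compound 2 (within the scatter), no change at the digits printed from compound 1 to compound 3 (within the scatter) and no change at the digits printed from compound 2 to compound 3 (within the scatter). None of these steps goes beyond the scatter, even though the groups differ from one another. The data hold no measured amide, however, and the entering group is larger than any group tested so far, so this reasoning stretches the evidence. Even so, no shift in either direction is the most reasonable expectation, and the expected size is no change at the digits printed from compound 3 to compound 4 (within the scatter). For compound 4 the estimated value is 10000 nM, with an expected range from 4000 nM to 16000 nM.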

Compound 4, half-maximal inhibitory concentration: 10000 nM
For compound 4 middle estimate and measured number coincide at the digits printed; measured number inside the range.
By their numbers in this assay, from the lowest: compounds 1, 2, 3 and 4 (each within the scatter of the next).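

Compound 4 brings the first amide to this place, on a saturated chain carbon bound to an aromatic nitrogen. Carboxy, with 3 heavy atoms and 1 hydrogen-bond donor, gives way to (diethylcarbamoyl)methyl, with 8 heavy atoms and 0 hydrogen-bond donors. Even so, this assay shows no change at the digits printed from compound 3 to compound 4 (within the scatter) and no change at the digits printed from compound 2 to compound 4 (within the scatter) and also no change at the digits printed from compound 1 to compound 4 (within the scatter) so across these four compounds neither the larger group nor the missing donor goes with any shift in the read-out. No measurement shown here offers an explanation for this flat result.

All four compounds share one value, so the set contains no group at this place that moves the read-out in either direction, and it cannot show what such a group would look like. Still open, from the compounds shown here alone, are an amine such as a 2-(diethylamino)ethyl chain, a ring-bearing group such as benzyl, and a plain hydrogen on the aromatic nitrogen, along with replacements for the methoxy groups elsewhere on the shared core.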